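The compounds below may be only part of what the source reports. "The series", "measured", "known", "first", "only" and "open" are said of these compounds alone.

Compound 1 `CCCCNc1nc(N)nc(C)c1C`: 3280 nM
Compound 2 `CCCCNc1nc(N)nc(C)c1CCCn1cccn1`: 1050 nM

Both were tested in an assay on HEK293 cells for agonist activity at Toll-like receptor 8 (Homo sapiens), read by spectrophotometry; on this read-out higher numbers stand for an effect only at larger amounts of compound and lower numbers for an effect already at smaller amounts. Compound 1 gives the highest of the two numbers; its nearest neighbour is compound 2, reached by a 3.1-fold lower number from compound 1 to compound 2 (0.49 log units; beyond the scatter). Compound 3 `CCCCNc1nc(N)nc(C)c1C#C[Si](C)(C)C` differs from compound 1 by a group of 6 heavy atoms (5 carbon, 1 silicon; no ring) in place of one carbon atom, on an aromatic carbon. That one measured step also replaced the methyl on the same aromatic carbon with a larger group, but the group entering here is of a different kind, so in this assay only a modest drop in number, or none beyond the scatter, is expected. Compound 3 is therefore expected to give 2000 nM, between 700 nM and 6000 nM, which would mean a 1.6-fold lower number from compound 1 to compound 3 (0.21 log units; within the scatter).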

Compound 3, half-maximal effective concentration: 9240 nM
Compound 3: the middle estimate sits 4.6-fold (0.66 log units) below what was measured; measured number outside the range, above it.
By their numbers in this assay, from the lowest: compound 2; then compound 1; then compound 3.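

The methyl on this aromatic carbon can give way to a larger group with the number moving either way: in this assay the silicon-bearing group with its triple bond gives a 2.8-fold higher number from compound 1 to compound 3 (0.45 log units; beyond the scatter), whereas the 2-(1H-pyrazol-1-yl)ethyl extension gives a 3.1-fold lower number from compound 1 to compound 2 (0.49 log units; beyond the scatter). A larger group at this position therefore does not by itself lower the number. Nothing available here explains why the two groups part ways. As far as these compounds go, whether a plain propyl chain would match compound 2, or whether an amine at the end of that chain would go lower still, remains open.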